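Series notes: aryl exchange on the core of compound 1

The source may report more compounds than this note shows. Statements on the series, on what has been measured and on what is new or still open speak of the compounds shown alone.

For the measured compounds named here, compound 1 `CC(c1ccc(-c2ccccc2)c(F)c1)c1nnc2n1N=C(c1ccc(Cl)cc1Cl)CS2` is the only member of this set with a numerical result. In a functional assay on FOCUS cells (Homo sapiens) for inhibition, read by sulforhodamine B assay, with a stated time of 72 h (on this read-out higher numbers stand for weaker inhibition and lower numbers for stronger inhibition), compound 1 gives 5400 nM. Compound 2 `COc1ccc2cc(C(C)c3n[nH]c(=S)n3N)ccc2c1` lacks the core of compound 1. In this assay, going by the values given here, compound 2 is reported as "not active" (no number reported), so no number is attached to it and no step between measured compounds can be drawn from these two entries. Compound 1 therefore stands alone as the reference point of the series, with nothing yet to rank it against.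

Compound 3 `CC(c1ccc(-c2ccccc2)c(F)c1)c1nnc2n1N=C(c1ccc(F)cc1)CS2` has not been measured. It keeps the core of compound 1 and differs in one place: 4-fluorophenyl in place of 2,4-dichlorophenyl on a carbon with a double bond to nitrogen. One six-membered aromatic ring of carbon only is exchanged for another, two chlorine atoms leaving and one fluorine entering.

Among the compounds with values here, with no measured pair to calibrate such an exchange, the step is expected to be modest, if anything toward weaker inhibition, a 1.7-fold higher number from compound 1 to compound 3 (0.22 log units; within the scatter) in this assay. Compound 3 is expected to give 9000 nM in this assay, with a plausible range from 3000 nM to 30000 nM.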

Compound 3, half-maximal inhibitory concentration: 3500 nM
Compound 3: the middle estimate sits 2.6-fold (0.41 log units) above what was measured; the measured number falls inside the stated range.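

For the compounds shown here, the exchange of 2,4-dichlorophenyl for 4-fluorophenyl on a carbon with a double bond to nitrogen gives a 1.5-fold lower number from compound 1 to compound 3 (0.19 log units; within the scatter) in this assay and so provides the first readable step. At this position, the two aryl groups cannot be told apart in this assay: two chlorine atoms can leave and one fluorine can enter without moving the result beyond the usual scatter, although this rests on a single pair. No evidence is at hand that bears on this result.

Going by these compounds alone, the pair covers only two halogen-bearing phenyl groups, so it remains open whether the position would accept a ring or group of another kind, such as a pyridine ring, a morpholine, a carboxylic acid or a longer alkyl chain. Also open is whether the phenyl ring needs any halogen at all, since the unsubstituted phenyl group and the 4-methoxyphenyl group are not among the compounds shown, and whether a step beyond the scatter can be reached here.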